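From 4-chlorobenzyl to 2-fluorobenzyl at the solubility limit

The source may hold more compounds than are shown below. What is called first, only, known or untested is meant among the compounds shown, and "the series" means these compounds.

- Compound 1 `O=C(O)c1ccc(C(=O)/C(=C\c2ccc(Cl)c([N+](=O)[O-])c2)SCc2ccc(Cl)cc2)cc1`: limit < 1000 ug/mL
- Compound 2 `O=C(O)c1ccc(C(=O)/C(=C\c2ccc(Br)c([N+](=O)[O-])c2)SCc2ccc(Cl)cc2)cc1`: limit < 1000 ug/mL
- Compound 3 `O=C(O)c1ccc(C(=O)/C(=C\c2ccc(F)c([N+](=O)[O-])c2)SCc2ccc(C(F)(F)F)cc2)cc1`: limit < 1000 ug/mL

In a physicochemical assay for solubility (on this read-out lower numbers stand for lower solubility and higher numbers for higher solubility), compound 1 stands only at a limit, < 1000 ug/mL, and has no exact number. The whole set rests on (the limit of < 1000 ug/mL in this assay, at which 3 of the 3 values shown sit). Compound 4 `O=C(O)c1ccc(C(=O)/C(=C\c2ccc(Cl)c([N+](=O)[O-])c2)SCc2ccccc2F)cc1` is still unmeasured and differs from compound 1 by 2-fluorophenyl in place of 4-chlorophenyl on a saturated chain carbon bound to a sulfur. For the measured compounds named here, the only measured step is a step that the two limits leave unreadable from compound 1 to compound 2, with bromo in place of chloro on an aromatic carbon, so it offers no size to carry over. No change beyond the scatter is therefore expected in this assay, and another limit is likely. The expected step is a step that the limit leaves unreadable from compound 1 to compound 4. Compound 4 is estimated at 700 ug/mL, with an expected range of 250 ug/mL to 1000 ug/mL.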

Compound 4, solubility: < 1000 ug/mL
Compound 4: no number, only a limit; the forecaster's own chance of this, stated with the estimate: 90%; the middle value is on the limit's open side.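

In this assay compound 4 gives < 1000 ug/mL, which is a limit and not a number. No new step can be read between compound 1 and compound 4. The compounds shown leave open how their solubilities compare with one another: the limit of < 1000 ug/mL in this assay, at which 4 of the 4 values shown sit.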